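Demethylation of a methoxy group under a cytotoxicity limit

The source may hold more compounds than are shown below. What is called first, only, known or untested is meant among the compounds shown, and "the series" means these compounds.

Compounds measured so far:
Compound 1, `Oc1ccccc1CNc1ncnc2c1ncn2C1CCCCO1`, reaches only the limit > 100000 nM in an ADME assay on BJ cells (Homo sapiens) for cytotoxicity, read by MTT assay, with a stated time of 72 h; on this read-out lower numbers stand for stronger inhibition and higher numbers for weaker inhibition.
Compound 2, `COc1ccccc1CNc1ncnc2c1ncn2C1CCCCO1`, likewise sits at the limit > 100000 nM in this assay.
Compound 3, `COc1cccc(CNc2ncnc3c2ncn3C2CCCCO2)c1O`, also gives only the limit > 100000 nM in this assay.

Compound 4, `Oc1cccc(CNc2ncnc3c2ncn3C2CCCCO2)c1O`, has not yet been measured. It differs from compound 3 by hydrogen in place of methyl on an oxygen on an aromatic ring, the same change that turns compound 2 into compound 1, (hydrogen in place of methyl on an oxygen on an aromatic ring), since the two place lines agree word for word. That earlier step, a step that the two limits leave unreadable from compound 2 to compound 1, cannot be sized, as both of its ends are limits; the step that the two limits leave unreadable from compound 1 to compound 3 is unreadable for the same reason. How the cores of compound 2 and compound 3 differ is not broken down here. Among the measured compounds shown here, the only evidence on these steps is the limit of > 100000 nM in this assay, at which 3 of the 3 values shown sit.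

Because of the limit of > 100000 nM in this assay, at which 3 of the 3 values shown sit, with no measured value below the limit among the three compounds, the step from compound 3 to compound 4 is expected to be small, a number no higher from compound 3 to compound 4 (the limit leaves the size open), and most likely to end again at a limit. Compound 4 is therefore estimated at 100000 nM, between 30000 nM and 300000 nM.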

Compound 4, half-maximal inhibitory concentration: 63300 nM
Estimate against measurement, compound 4: 1.6-fold (0.20 log units) above, within the range that was stated.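

In this assay, the change of methoxy to hydroxy on the core of compound 3 gives an at least 1.5-fold lower number from compound 3 to compound 4 (0.19 log units; that floor lies within the scatter), and the two wider comparisons give an at least 1.5-fold lower number from compound 1 to compound 4 (0.19 log units; that floor lies within the scatter) and an at least 1.5-fold lower number from compound 2 to compound 4 (0.19 log units; that floor lies within the scatter). The same change on the other core cannot be sized, nor can the other step among the first three compounds, so no two sizes can be set side by side, because those values all stop at one limit: the limit of > 100000 nM in this assay, at which 3 of the 4 values shown sit. Among the compounds shown here, the result therefore shows only that compound 4 is the one compound here with a measured number; it does not show that the change acts alike on both cores, and with each floor within the scatter it does not establish a real shift on either.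

The compounds shown leave open how this assay would read if an amine or a carboxylic acid stood in place of a hydroxy on the aromatic ring. They also leave open what a longer chain would do in place of the saturated chain carbon bound to the nitrogen.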